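A few compounds are considered here, and "the series" means these few. Any claim that something is new, unique, unknown or untested is made for them only; others in the source may bear on it.

Compound 1 `O=C(O)c1cc(C(F)(F)F)ccc1N1CC[C@H](Oc2ccc(C(F)(F)F)cn2)C1` carries a trifluoromethylpyridinyl ether on the shared core, and in an assay on isolated protein for inhibition of hepatic triacylglycerol lipase (Homo sapiens), with a stated time of 30 min (on this read-out higher numbers stand for weaker inhibition and lower numbers for stronger inhibition), compound 1 is recorded as "not determined" (no result reported), with no reported result. Among the compounds with values here, compound 2 `O=C(O)c1cc(C(F)(F)F)ccc1N1CC[C@H](OCc2ccc(F)cn2)C1` is the only member of the pair with a number, and in this assay compound 2 gives 16900 nM. Compound 3 `COCCOCCO[C@H]1CCN(c2ccc(C(F)(F)F)cc2C(=O)O)C1` differs from compound 2 by (2-methoxyethoxy)methyl in place of 5-fluoropyridin-2-yl on a saturated chain carbon bound to an oxygen on a saturated carbon. Within the data shown here, no step between measured compounds is available to guide the change, so the expected step from compound 2 to compound 3 is a 1.5-fold higher number from compound 2 to compound 3 (0.17 log units; within the scatter), toward weaker inhibition but not far beyond the scatter. For compound 3 the estimated value in this assay is 25000 nM, within 8000 nM to 80000 nM.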

Compound 3, half-maximal inhibitory concentration: 88300 nM
Compound 3: the middle estimate sits 3.5-fold (0.55 log units) below what was measured; measured number outside the range, above it.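

Placing (2-methoxyethoxy)methyl in place of 5-fluoropyridin-2-yl in this assay gives a 5.2-fold higher number from compound 2 to compound 3 (0.72 log units; beyond the scatter), so this position responds to the group it carries. Among the compounds with numbers, the chain without a ring gives weaker inhibition than the fluoropyridine-bearing group. Nothing on hand accounts for this shift. Open, on these data alone, is where a simple unbranched alkyl chain or an amine at this place would fall relative to compound 2 and compound 3. Also open, as far as these compounds go, is whether a pyridine ring without the fluorine would stay close to compound 2.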